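The compounds below may be only part of what the source reports. "The series", "measured", "known", "first", "only" and "open" are said of these compounds alone.

In a functional assay on RS4-11 cells (Homo sapiens) for inhibition, read by CCK-8 assay, with a stated time of 48 h (a lower number here means a stronger inhibitor, a higher number a weaker inhibitor), compound 1 `O=C(NCCNS(=O)(=O)c1ccc(-c2ccccc2O[C@H]2CC[C@H](O)CC2)s1)Nc1cc(C(F)(F)F)cc(C(F)(F)F)c1` gives 10100 nM as its reading, and compound 3 `O=S(=O)(NCCNC(=S)Nc1cc(C(F)(F)F)cc(C(F)(F)F)c1)c1ccc(-c2ccccc2O[C@H]2CC[C@@H](O)CC2)s1` gives 6300 nM as its reading. These two values lie within the usual scatter of each other, so compound 1 cannot be ranked apart from compound 3. Compound 2 `COc1ccc(Oc2ccc([N+](=O)[O-])cc2-c2ccsc2S(=O)(=O)N2CCN(C(=S)Nc3ccc([N+](=O)[O-])cc3)CC2)cc1OC` is reported as > 50000 nM in this assay and that is a limit of the assay, not a number.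

Compound 4 `O=C(NCCNS(=O)(=O)c1ccc(-c2ccccc2Oc2ccc(O)c(O)c2)s1)Nc1cc(C(F)(F)F)cc(C(F)(F)F)c1` keeps the core of compound 1 and changes one group. The counted difference is 3,4-dihydroxyphenyl in place of 4-hydroxycyclohexyl on an oxygen on an aromatic ring and in words it is 3,4-dihydroxyphenyl in place of 4-hydroxycyclohexyl on an oxygen on an aromatic ring. For the measured compounds named here, no pair of measured compounds shows this swap, so the data give no direct guide to its size or direction. The starting point is compound 1 at 10100 nM and a non-aromatic ring gives way there to an aromatic one, a sizeable change in kind. The estimated step is a 2.5-fold lower number from compound 1 to compound 4 (0.40 log units; beyond the scatter) and it is expected to be modest, toward a stronger inhibitor, though no change beyond the scatter remains possible. In this assay the expected value for compound 4 is 4000 nM and the estimated range runs from 1000 nM to 15000 nM overall.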

Compound 4, half-maximal inhibitory concentration: 4900 nM
Compound 4: the middle estimate sits 1.2-fold (0.09 log units) below what was measured; low and high end bracket the measured number.
By their numbers in this assay, from the lowest: compounds 4, 3 and 1 (each within the scatter of the next, the first and the last beyond it). At a limit, above all of these: compound 2.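

Placing 3,4-dihydroxyphenyl in place of 4-hydroxycyclohexyl on the oxygen on the aromatic ring gives, in this assay, a 2.1-fold lower number from compound 1 to compound 4 (0.31 log units; beyond the scatter), the first step measured at this position. It shows that the reading responds to the group carried here and that an aromatic ring can take the place of a non-aromatic one without a weaker inhibitor resulting, although the step is modest. The swap alters several things at once, since the entering group has a different ring type, more hydrogen-bond donors and acceptors, and no defined stereocentres, and nothing measured here says which of these matters.

The compounds shown leave open whether both hydroxyl groups on the phenyl ring are needed, which a phenyl ring with a single hydroxyl or with methoxy groups instead would help to settle. They also leave open how this position would respond to a different kind of group, such as an amine or a carboxylic acid on the ring, and whether the same swap would give a similar step on the thiourea series represented by compound 3.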